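Ester to Carbamoyl: Estimating the Amide Analogue of Compound 1

The compounds below may be only part of what the source reports. "The series", "measured", "known", "first", "only" and "open" are said of these compounds alone.

Of the compounds shown here, three have so far been tested in an assay for inhibition of Fatty-acid amide hydrolase 1 (Rattus norvegicus); a lower number here means a stronger inhibitor, a higher number a weaker inhibitor. Compound 1 `CCOC(=O)c1cccc(-c2cnc(C(=O)CCc3ccc(-c4ccccc4)cc3)o2)n1` gives 3 nM in this assay. Compound 2 `NC(=O)c1cnc(C(=O)CCc2ccc(Oc3ccccc3)cc2)o1` gives 6.6 nM, a somewhat higher number, while compound 3 `N#Cc1cccc(-c2cnc(C(=O)CCc3ccc(COc4ccccc4)cc3)o2)n1` gives 0.56 nM, clearly lower. Compound 1 thus stands second highest of the three, nearer to compound 2 than to compound 3.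

Compound 4 `NC(=O)c1cccc(-c2cnc(C(=O)CCc3ccc(-c4ccccc4)cc3)o2)n1` has not yet been measured. It differs from compound 1 in a single place: amino in place of ethoxy on a carbonyl carbon. For the measured compounds named here, no pair of measured compounds isolates this change, and compound 2 carries its carbamoyl at a different position with a different tail, so it offers no direct comparison. The change from ethoxycarbonyl to carbamoyl is expected to produce only a small step, a 1.3-fold higher number from compound 1 to compound 4 (0.12 log units; within the scatter), with no confident direction beyond the scatter. Compound 4 is therefore estimated at 4 nM, within a range from 1.2 nM to 13 nM.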

Compound 4, inhibition constant: 1.2 nM
The estimate for compound 4 lay 3.3-fold (0.52 log units) above the measured number; measured number inside the range.
By their numbers in this assay, from the lowest: compound 3; then compound 4; then compound 1; then compound 2.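

Amino in place of ethoxy on a carbonyl carbon gives a 2.5-fold lower number from compound 1 to compound 4 (0.40 log units; beyond the scatter) in this assay and is the first change here that can be read in isolation. The ethoxy is therefore not required for a low number at this place, and the carbamoyl is at least as well tolerated on the core of compound 1. Nothing at hand explains this step.

As far as these compounds go, whether a carboxylic acid or a methylamino amide on the same carbonyl carbon would go further remains open. So does whether this step holds with the tails of compound 2 and compound 3.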